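A few compounds are considered here, and "the series" means these few. Any claim that something is new, unique, unknown or untested is made for them only; others in the source may bear on it.

Measured compounds:
compound 1 `COc1cc(-c2cc(/C=C/C(=O)c3ccc(Cl)c(Cl)c3)[nH]n2)cc(OC)c1OC` — -15%
compound 2 `COc1ccc(C(=O)/C=C/c2cc(-c3cc(OC)c(OC)c(OC)c3)n[nH]2)cc1` — -16%

In a functional assay on CCRF-CEM cells (Homo sapiens) for cytotoxicity, read by sulforhodamine B assay, with a stated time of 48 h, tested at 100 uM (on this read-out lower numbers stand for a stronger effect and higher numbers for a weaker effect at the one concentration tested), compound 2 sits alongside compound 1, the two numbers within the usual scatter of each other, so neither is told apart from the other. Compound 3 `COc1cc(-c2cc(/C=C/C(=O)c3ccc(F)c(F)c3)[nH]n2)cc(OC)c1OC` differs from compound 2 by 3,4-difluorophenyl in place of 4-methoxyphenyl on a carbonyl carbon. Within the data shown here, the one measured step bearing on this, a number 1 percentage points lower from compound 1 to compound 2 (within the scatter), also exchanged the group on the carbonyl carbon and moved nothing beyond the scatter. The expected step is a number 1 percentage points higher from compound 2 to compound 3 (within the scatter), nothing beyond the scatter. Compound 3 is estimated at -15%, with a range from -35% to 5%.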

Compound 3, a percentage reported as activity, at one concentration (the size of the read-out at that concentration, not a potency): -4%
Beside the measured number, compound 3's estimate is 11 percentage points below it; the measured number falls inside the stated range.
By their numbers in this assay, from the lowest: compounds 2 and 1 (each within the scatter of the next); then compound 3.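

In this assay the group on the carbonyl carbon now makes a difference: 3,4-difluorophenyl gives a number 12 percentage points higher from compound 2 to compound 3 (beyond the scatter) and also a number 11 percentage points higher from compound 1 to compound 3 (beyond the scatter) while 4-methoxyphenyl and 3,4-dichlorophenyl remain within the scatter of each other. This position is therefore not indifferent to the exchange, and compound 3 is the weakest of the three at the one concentration tested. Nothing at hand offers a reason for this shift.

Still open, from the compounds shown here alone, is how an amine or a carboxylic acid on the carbonyl carbon would read in this assay and whether these steps would hold at lower concentrations.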